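The compounds below may be only part of what the source reports. "The series", "measured", "known", "first", "only" and "open" are said of these compounds alone.

Measured compounds:
compound 1, `O=c1nc2oc(C3CC3)cc2cn1Cc1cn(-c2ccc(Cl)cc2)nn1`: 61000 nM
compound 2, `CCCCCc1ccc(C#Cc2c(-c3ccc(CCCCC)cc3)oc3nc(=O)n(Cc4cn(-c5ccc(Cl)cc5)nn4)cc23)cc1`: > 100000 nM
compound 3, `CCCCCCC#Cc1c(CCCCCC)oc2nc(=O)n(Cc3cn(-c4ccc(F)cc4)nn3)cc12`: > 100000 nM

In a functional assay on A549 cells (Homo sapiens) for antiproliferative activity, read by MTT assay, with a stated time of 72 h (on this read-out higher numbers stand for weaker inhibition and lower numbers for stronger inhibition), compound 1 gives 61000 nM, and this is the only actual number among the three results shown. For compound 2 the result is a limit of the assay, > 100000 nM. For compound 3 the result is likewise a limit of the assay, > 100000 nM. Compound 1 therefore stands alone with a measured value, while the other two sit at the limit of > 100000 nM in this assay, at which 2 of the 3 values shown sit.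

Compound 4, `O=c1nc2oc(CCCCl)cc2cn1Cc1cn(-c2ccc(Cl)cc2)nn1`, has not yet been measured. It differs from compound 1 at one place: 3-chloropropyl in place of cyclopropyl on an aromatic carbon. The core and the remainder of compound 1 are kept unchanged. For the measured compounds named here, no two of the measured compounds differ in only one place, so no measured step is available to guide the expectation. With a modest exchange of one small group for another at the same place, the step of a 1.0-fold lower number from compound 1 to compound 4 (0.01 log units; within the scatter) is expected to be small, within the usual scatter of this assay, in no firm direction. Compound 4 is accordingly estimated at 60000 nM, with a range from 25000 nM to 150000 nM.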

Compound 4, half-maximal inhibitory concentration: 52000 nM
Estimate against measurement, compound 4: 1.2-fold (0.06 log units) above, within the range that was stated.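

In this assay, for the compounds shown here, the exchange of cyclopropyl for 3-chloropropyl on an aromatic carbon next to the ring oxygen provides the first step that can be read at this position, with a 1.2-fold lower number from compound 1 to compound 4 (0.07 log units; within the scatter). For this one pair, the three-membered ring can therefore give way to an open chain carrying a chlorine without a change beyond the scatter. Compound 4 also gives an actual number, as compound 1 does, while the other results shown are limits of the assay: the limit of > 100000 nM in this assay, at which 2 of the 4 values shown sit.

As far as these compounds go, whether plain propyl, without the chlorine, would behave like 3-chloropropyl remains open. From the compounds shown here alone, it is also open whether an amine, a carboxylic acid or a longer chain at this place would shift the number beyond the scatter.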